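The source may report more compounds than this note shows. Statements on the series, on what has been measured and on what is new or still open speak of the compounds shown alone.

In a functional assay on A549 cells (Homo sapiens) for antiproliferative activity, read by sulforhodamine B assay, with a stated time of 48 h (on this read-out lower numbers stand for stronger inhibition and higher numbers for weaker inhibition), compound 1 `COc1ccc(-c2oc3c(OC)c(OC)cc(OCCCCC(=O)NCc4ccccn4)c3c(=O)c2O)cc1` gives > 40000 nM, which is a limit of the assay. As far as these compounds go, compound 2 `COc1ccc(-c2oc3c(OC)c(OC)cc(OCCCCC(=O)N4CCN(C)CC4)c3c(=O)c2O)cc1` gives > 40000 nM, which is also a limit, so its true position is unknown. Compound 3 `CCCCCN(C)C(=O)CCCCCOc1cc(OC)c(OC)c2oc(-c3ccc(OC)cc3)c(O)c(=O)c12` differs from compound 2 by (methyl(pentyl)carbamoyl)methyl in place of (4-methylpiperazin-1-yl)carbonyl on a saturated chain carbon, four bonds along the chain from an oxygen on an aromatic ring. Among the compounds with values here, the only measured evidence is a step that the two limits leave unreadable from compound 1 to compound 2, so no size can be carried over, and any forecast remains loose. The expected change is an at least 1.6-fold lower number from compound 2 to compound 3 (0.20 log units; that floor lies within the scatter), tentatively toward stronger inhibition. For compound 3, the estimated value is 25000 nM, within an expected range of 6000 nM to 60000 nM.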

Compound 3, half-maximal inhibitory concentration: 17200 nM
Compound 3: the middle estimate sits 1.5-fold (0.16 log units) above what was measured; measured number inside the range.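

In this assay, the open-chain (methyl(pentyl)carbamoyl)methyl in place of the ring-bearing (4-methylpiperazin-1-yl)carbonyl gives an at least 2.3-fold lower number from compound 2 to compound 3 (0.36 log units; beyond the scatter), so this position can respond to a change of group. The same group in place of ((pyridin-2-yl)methyl)carbamoyl gives an at least 2.3-fold lower number from compound 1 to compound 3 (0.36 log units; beyond the scatter). Both steps are only floors, and the step between compound 1 and compound 2 cannot be read: the limit of > 40000 nM in this assay, at which 2 of the 3 values shown sit.

The compounds shown do not separate the loss of the ring from the arrival of the pentyl chain. As far as these compounds go, how a hexyl group in place of the pentyl, or a carboxylic acid at this place, would read also stays open.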